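Extra aromatic ring on the arylmethyl piperazine arm

The source may hold more compounds than are shown below. What is called first, only, known or untested is meant among the compounds shown, and "the series" means these compounds.

Of the compounds shown here, two on the shared core have been measured in an assay on isolated protein for displacement of a labelled ligand from Apoptosis regulator Bcl-2 (Homo sapiens), read by fluorescence polarization; a higher number here means a weaker inhibitor, a lower number a stronger inhibitor. Compound 1 `COC1(Cc2ccccc2-c2ccccc2)CCN(c2ccc(C(=O)NS(=O)(=O)c3ccc(N[C@H](CCN(C)C)CSc4ccccc4)c([N+](=O)[O-])c3)cc2)CC1` returns < 1 nM, which is a limit of the assay rather than a number. Within the data shown here, compound 2 `COc1ccccc1CN1CCN(c2ccc(C(=O)NS(=O)(=O)c3ccc(N[C@H](CCN(C)C)CSc4ccccc4)c([N+](=O)[O-])c3)cc2)CC1` gives 3.2 nM in this assay, the only numerical value in the set, so it stands as the single fixed point; no order between compound 2 and compound 1 can be stated. Among the measured compounds shown here, no pair of measured compounds differs in one place, so no measured step is available.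

Compound 3 `COc1ccc(-c2ccccc2CN2CCN(c3ccc(C(=O)NS(=O)(=O)c4ccc(N[C@H](CCN(C)C)CSc5ccccc5)c([N+](=O)[O-])c4)cc3)CC2)cc1` is not yet measured. It differs from compound 2 by 4-methoxyphenyl in place of methoxy on an aromatic carbon. Compound 1, which also carries two linked aromatic rings on its own arylmethyl arm, sits at the limit of < 1 nM in this assay, at which 1 of the 2 values shown sits. On that basis the step from compound 2 to compound 3 in this assay is expected to be a 2.7-fold lower number from compound 2 to compound 3 (0.43 log units; beyond the scatter), a gain beyond the scatter but not a large one. Compound 3 is estimated at 1.2 nM, within 0.4 nM to 4 nM, with a fair chance that the assay reports only a limit.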

Compound 3, inhibition constant: < 1 nM
Compound 3 gave a limit, no number (the forecaster's own chance of this, stated with the estimate: 40%); middle value at least 1.2-fold (0.07 log units) away from the limit.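

On an aromatic carbon ortho to a large group, the arylmethyl arm accepts 4-methoxyphenyl in place of methoxy, an exchange of 2 heavy atoms for 8 that adds a six-membered aromatic ring, and in this assay this exchange gives an at least 3.2-fold lower number from compound 2 to compound 3 (0.50 log units; beyond the scatter). Compound 3 stands at < 1 nM, which is a limit of the assay and not a number. This is the first measured step in the series, and it fixes only a minimum for the gain, so its full size cannot be read: the limit of < 1 nM in this assay, at which 2 of the 3 values shown sit.

The compounds shown do not separate the contribution of the added ring from that of its methoxy, and the response to an unsubstituted phenyl, a pyridine ring or a carboxylic acid at this carbon remains open. Further changes on this arm can only be ranked against compound 3 in a read-out that gives numbers below the present limit.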